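This account rests on a few compounds, and the source may have more. Where it says the series, first, only, none or still open, it means among the compounds named here.

Working notes on the series. In an ADME assay on microsomes from liver (Mus musculus) for metabolic stability, using NADPH, with a stated time of 10 min (on this read-out lower numbers stand for a less stable compound and higher numbers for a more stable compound), compound 1 (`CCCCc1nc(=O)c(S(=O)(=O)c2ccc(-c3ccc(F)nc3)cc2)c(O)n1-c1c(OC)cccc1OC`) gives 69%, the highest of the three measured numbers. Compound 2 (`CCCCc1[nH]c(=O)c(S(=O)(=O)c2ccc(-c3ccncc3C)cc2)c(O)c1-c1c(OC)cccc1OC`) gives 39% and compound 3 (`COc1cccc(OC)c1-n1c(CCC(C)C)nc(=O)c(S(=O)(=O)c2ccc(-c3ccc(F)nc3)cc2)c1O`) gives 31%, both beyond the scatter from compound 1.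

The next comparison is compound 4 (`CCCCc1nc(=O)c(S(=O)(=O)c2ccc(C3CC3)cc2)c(O)n1-c1c(OC)cccc1OC`), which carries cyclopropyl in place of the 6-fluoropyridin-3-yl of compound 1, on an aromatic carbon para to a large group: cyclopropyl in place of 6-fluoropyridin-3-yl on an aromatic carbon.

Among the compounds with values here, only one measured step changes a single place: a number 38 percentage points lower from compound 1 to compound 3 (beyond the scatter), a large step beyond the scatter, with methyl in place of hydrogen on a saturated chain carbon. That change lies elsewhere in the molecule, so it gives no direct reading on the new one. Within the data shown here, no measured step replaces the 6-fluoropyridin-3-yl. The step does show that one small change can move this assay a long way, so a wide range is warranted.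

With compound 1 at 69%, the top of the three numbers, a fall is expected more readily than a rise, though the data cannot fix its direction firmly. The expected change is a number 14 percentage points lower from compound 1 to compound 4 (beyond the scatter), smaller than the measured step. The estimate for compound 4 is 55%, with an expected range from 30% to 78%.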

Compound 4, percent of the compound remaining: 93%
Estimate against measurement, compound 4: 38 percentage points below, and the stated range ends below it.
By their numbers in this assay, from the lowest: compounds 3 and 2 (each within the scatter of the next); then compound 1; then compound 4.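

Within the data shown here, the only single-place step measured earlier lay on the chain, whereas a number 24 percentage points higher from compound 1 to compound 4 (beyond the scatter) shows that the aromatic carbon para to a large group also moves the number in this assay, and here upward. The change is composite: a six-membered aromatic ring with 1 hetero atom and 7 heavy atoms gives way to a three-membered non-aromatic ring of carbon only with 3 heavy atoms, while the nitrogen, the fluorine and the hydrogen-bond acceptor all leave together, so this one step cannot assign the rise to any single one of these differences. No measurement shown here offers an explanation for the step.

The compounds shown leave open whether the number follows ring size, aromatic character or the loss of the fluorine and nitrogen, a question that phenyl, 4-fluorophenyl, cyclobutyl or a simple ethyl chain at this carbon would help to separate. They also leave open whether cyclopropyl at this position would give a similar step when paired with the branched chain of compound 3, and whether an amine or a carboxylic acid would be tolerated here.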